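Piperidinyl in place of isopropyl on an inactive compound

The compounds below may be only part of what the source reports. "The series", "measured", "known", "first", "only" and "open" are said of these compounds alone.

Compound 1, `Cc1ccc2nc(Nc3nc(Nc4ccc(S(N)(=O)=O)cc4)ncc3F)sc2c1`, gives 4960 nM in a functional assay on PC-3 cells (Homo sapiens) for antiproliferative activity, read by MTT assay, with a stated time of 48 h; a lower number here means a stronger inhibitor, a higher number a weaker inhibitor.
Compound 2, `Cc1cnc(Nc2ccc(C(C)C)cc2)nc1Nc1nc2ccccc2s1`, reaches only the limit of this assay, > 50000 nM.
Compound 3, `COc1ccc2nc(Nc3nc(Nc4ccc(S(C)(=O)=O)cc4)ncc3F)sc2c1`, gives 1270 nM in this assay.

Of the three measured compounds, only compound 1 and compound 3 carry a numeric reading, and both sit well apart from the limit at which compound 2 stands (the limit of > 50000 nM in this assay, at which 1 of the 3 values shown sits). Compound 2 thus occupies the weak end of what has been seen here, with no number of its own.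

The step under consideration leads from compound 2 to compound 4, `Cc1cnc(Nc2ccc(N3CCCCC3)cc2)nc1Nc1nc2ccccc2s1`. The change is piperidin-1-yl in place of isopropyl on an aromatic carbon; in words, piperidin-1-yl in place of isopropyl on an aromatic carbon. The remainder of compound 2 is kept unchanged. Going by the values given here, no comparable pair has been measured in this assay, so the size and direction of the step rest on no precedent.

Given that compound 2 sits at the limit, compound 4 is expected to stay in the weak region, with a step of an at least 1.4-fold lower number from compound 2 to compound 4 (0.15 log units; that floor lies within the scatter) as the estimate. The estimate for compound 4 in this assay is 35000 nM, within a range from 6000 nM to 150000 nM, with a sizable chance that only a limit is reported again.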

Compound 4, half-maximal inhibitory concentration: > 50000 nM
Compound 4 ended at the assay's limit; the forecaster's own chance of this, stated with the estimate: 55%; middle value at least 1.4-fold (0.15 log units) away from the limit.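

Compound 2 and compound 4 both end at a limit of this assay rather than at a number, so the step between them cannot be read: the limit of > 50000 nM in this assay, at which 2 of the 4 values shown sit.

The compounds shown leave open whether piperidin-1-yl in place of isopropyl on an aromatic carbon changes the reading in this assay at all, and in which direction.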